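The source may hold more compounds than are shown below. What is called first, only, known or untested is meant among the compounds shown, and "the series" means these compounds.

Measured in a functional assay on Bel-7402 cells (Homo sapiens) for inhibition, read by MTT assay, with a stated time of 24 h, tested at 10 ug/mL; on this read-out lower numbers stand for less inhibition of growth and higher numbers for more inhibition of growth at the one concentration tested:
- Compound 1 `O=C(O)CCCCC(CCSC(=O)c1ccccc1)SC(=O)c1ccccc1`: 2.76%
- Compound 2 `O=C(CCCCC(S)CCS)Nc1ccccc1Cl`: "not active" (no number reported)

Among the measured compounds shown here, compound 1 holds the only actual number in this assay, and at 2.76% it shows very little growth inhibition. Compound 2 was reported without a number.

Compound 3 `O=C(CCCCC(CCSC(=O)c1ccccc1)SC(=O)c1ccccc1)Nc1ccccc1` has not yet been measured. It keeps the core of compound 1 but carries anilino in place of hydroxy on a carbonyl carbon, so carboxy becomes phenylcarbamoyl (anilino in place of hydroxy on a carbonyl carbon). For the measured compounds named here, no pair of measured compounds shows this change on its own, so the data offer no direct guide.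

With compound 1 at 2.76%, there is little room to fall, so a slight rise is the likeliest outcome. The expected step of a number 5.2 percentage points higher from compound 1 to compound 3 (within the scatter) is small and probably stays within the usual scatter. For compound 3 the estimated value is 8%, with an expected range from 0% to 25%.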

Compound 3, percent growth inhibition at one concentration: "not active" (no number reported)
No number was reported for compound 3, and the estimate cannot be compared.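

Among the compounds shown here, compound 3 is reported in this assay as "not active", without a number, and no step from compound 1 to compound 3 can be read. As far as these compounds go, whether phenylcarbamoyl in place of carboxy changes growth inhibition at all stays open. No measurement shown here bears on this result.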